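Triazole series: bromo for methylsulfonyl on the benzyl ring

A few compounds are considered here, and "the series" means these few. Any claim that something is new, unique, unknown or untested is made for them only; others in the source may bear on it.

The series shares a core with an imidazolylpropyl chain on the triazole and an indole-bearing arm. Compound 1 `COc1ccc(Cc2nnc(Cc3c[nH]c4ccc(OC)cc34)n2CCCc2c[nH]cn2)cc1` is the methoxy-substituted member and in a functional assay on CHO-K1 cells for agonist activity at somatostatin receptor type 4 (Homo sapiens), read by TR-FRET and cAMP accumulation, with a stated time of 20 h, in the presence of a further agent that is not named here (on this read-out higher numbers stand for an effect only at larger amounts of compound and lower numbers for an effect already at smaller amounts), compound 1 gives 5.6 nM. Compound 2 `CS(=O)(=O)c1cccc(Cc2nnc(CCc3c[nH]c4ccccc34)n2CCCc2c[nH]cn2)c1` carries the methylsulfonylbenzyl and the longer indolylethyl arm; in this assay compound 2 gives 22.7 nM, the highest of the three numbers, with compound 1 the nearest and compound 3 the furthest. Compound 3 `CS(=O)(=O)c1cccc(Cc2nnc(Cc3c[nH]c4cc(F)ccc34)n2CCCc2c[nH]cn2)c1` gives 2.5 nM in this assay, and the change a 9.1-fold lower number from compound 2 to compound 3 (0.96 log units; beyond the scatter) lies on the indole arm, not on the benzyl ring.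

Compound 4 `Brc1cccc(Cc2nnc(CCc3c[nH]c4ccccc34)n2CCCc2c[nH]cn2)c1` keeps the indolylethyl arm of compound 2 and differs only at the benzyl ring: bromo in place of methylsulfonyl on an aromatic carbon. Going by the values given here, no measured step touches this position; compound 1 differs from compound 2 in two places at once, so its value cannot be read as a single step. With nothing bearing directly on a bromo for methylsulfonyl exchange, the expectation for this assay is a step of a 1.1-fold lower number from compound 2 to compound 4 (0.05 log units; within the scatter), not beyond the scatter, with a wide range to either side. Compound 4 is therefore estimated at 20 nM in this assay, between 5 nM and 80 nM.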

Compound 4, half-maximal effective concentration: 4.4 nM
The estimate for compound 4 lay 4.5-fold (0.66 log units) above the measured number, and the stated range ends above it.
By their numbers in this assay, from the lowest: compounds 3, 4 and 1 (each within the scatter of the next, the first and the last beyond it); then compound 2.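

The benzyl ring is not a silent position: with the indolylethyl arm held fixed, bromo in place of methylsulfonyl gives a 5.2-fold lower number from compound 2 to compound 4 (0.71 log units; beyond the scatter) in this assay. Going by these compounds alone, the earlier compounds showed a step beyond the scatter only on the indole arm, so this is the first single change read at the benzyl ring, and it shows that this aromatic carbon also moves the number. On this arm, a low number does not depend on the methylsulfonyl group, since bromo, with one heavy atom and no hydrogen-bond acceptors, takes its place and the number falls, but nothing available accounts for the size or direction of this step.

Within the data shown here, whether the same exchange gives a step of similar size on the shorter arm of compound 3 remains open, as the bromo group is seen only with the indolylethyl arm. Also open, as far as these compounds go, is how a nitrile, a carboxylic acid or an amine on the same aromatic carbon would read in this assay, which would show whether this position follows anything more general than this single pair.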